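1,3-Thiazol-2-yl replaces pyrimidin-2-yl on a sulfonamide nitrogen

This account rests on a few compounds, and the source may have more. Where it says the series, first, only, none or still open, it means among the compounds named here.

In a functional assay on MCF7 cells (Homo sapiens) for antiproliferative activity, read by sulforhodamine B assay, with a stated time of 72 h (on this read-out higher numbers stand for weaker inhibition and lower numbers for stronger inhibition), compound 2 `O=S(=O)(Nc1ncccn1)c1ccc(Nc2nncc3ccccc23)cc1` gives 64 nM, the highest of the three numbers at hand. Compound 1 `Cc1cc(C)nc(NS(=O)(=O)c2ccc(Nc3nncc4ccccc34)cc2)n1` gives 7.7 nM, and compound 3 `Clc1ccc(C(/C=C/c2ccccc2)=N\Nc2nncc3ccccc23)cc1` gives 3.6 nM. Compound 4 `O=S(=O)(Nc1nccs1)c1ccc(Nc2nncc3ccccc23)cc1` carries 1,3-thiazol-2-yl in place of pyrimidin-2-yl on a sulfonamide nitrogen. Within the data shown here, only one measured step bears on this place, an 8.3-fold higher number from compound 1 to compound 2 (0.92 log units; beyond the scatter), a modest one beyond the scatter. Among the measured compounds shown here, no measured step covers this ring exchange itself, so a step of similar or smaller size is expected. The direction is uncertain, with a slight lean toward a lower number, given that compound 2 at 64 nM stands highest. The expected step is a 2.1-fold lower number from compound 2 to compound 4 (0.33 log units; beyond the scatter). Compound 4 is estimated at 30 nM, with an expected range of 8 nM to 110 nM.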

Compound 4, half-maximal inhibitory concentration: 55 nM
The estimate for compound 4 lay 1.8-fold (0.26 log units) below the measured number; the range from low to high includes it.
By their numbers in this assay, from the lowest: compound 3; then compound 1; then compounds 4 and 2 (each within the scatter of the next).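

In this assay the exchange of pyrimidin-2-yl for 1,3-thiazol-2-yl on the sulfonamide nitrogen does not separate the two rings (a 1.2-fold lower number from compound 2 to compound 4 (0.07 log units; within the scatter)). The 4,6-dimethylpyrimidin-2-yl group of compound 1 stands apart from the thiazole as well (a 7.1-fold higher number from compound 1 to compound 4 (0.85 log units; beyond the scatter)), so this position does respond to the group it carries, though not to this ring exchange. Nothing at hand gives a reason for either result. On these data alone, what remains open is whether a single methyl on the pyrimidine would suffice, and how 4,6-dimethoxypyrimidin-2-yl or a 5-methyl-1,3-thiazol-2-yl group would read here.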